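Removing one methoxy from the aryl ketone of compound 3

A few compounds are considered here, and "the series" means these few. Any claim that something is new, unique, unknown or untested is made for them only; others in the source may bear on it.

Of the compounds shown here, three with a shared core have been measured in a functional assay on UACC-62 cells (Homo sapiens) for inhibition, read by sulforhodamine B assay, with a stated time of 48 h; on this read-out lower numbers stand for stronger inhibition of growth and higher numbers for weaker inhibition of growth. Compound 1 `COc1cc(-c2cc(/C=C/C(=O)c3ccc(N)cc3)[nH]n2)cc(OC)c1OC` gives 1700 nM, compound 2 `COc1cc(-c2cc(/C=C/C(=O)c3ccc(Cl)c(Cl)c3)[nH]n2)cc(OC)c1OC` gives 18800 nM, and compound 3 `COc1ccc(C(=O)/C=C/c2cc(-c3cc(OC)c(OC)c(OC)c3)n[nH]2)cc1OC` gives 1740 nM. Compound 3 therefore stands second highest of the three numbers: its nearest neighbour is compound 1, as a 1.0-fold higher number from compound 1 to compound 3 (0.01 log units; within the scatter) shows, while its furthest is compound 2, as an 11-fold lower number from compound 2 to compound 3 (1.03 log units; beyond the scatter) shows. The step of an 11-fold higher number from compound 1 to compound 2 (1.04 log units; beyond the scatter) completes the picture, all three steps exchanging the whole aryl group on the carbonyl carbon.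

Compound 4 `COc1ccc(C(=O)/C=C/c2cc(-c3cc(OC)c(OC)c(OC)c3)n[nH]2)cc1` differs from compound 3 by hydrogen in place of methoxy on an aromatic carbon — on an aromatic carbon of a six-membered aromatic ring of carbon only, ortho to a methoxy group and meta to a large group. Among the compounds with values here, no measured step removes a single methoxy; the steps seen swap entire aryl groups, with the 3,4-dichlorophenyl change large and the 4-aminophenyl to 3,4-dimethoxyphenyl change within the scatter. Compound 4 is expected to lie close to compound 3, with a step of a 1.3-fold higher number from compound 3 to compound 4 (0.10 log units; within the scatter) in this assay, an estimate of 2200 nM spanning 800 nM to 6000 nM.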

Compound 4, concentration for 50% growth inhibition: 1850 nM
For compound 4 the middle estimate is 1.2-fold (0.08 log units) above the measured one; the measured number falls inside the stated range.
By their numbers in this assay, from the lowest: compounds 1, 3 and 4 (each within the scatter of the next); then compound 2.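

Taken alone, the methoxy on this aromatic carbon makes no difference beyond the scatter in this assay: hydrogen in its place gives a 1.1-fold higher number from compound 3 to compound 4 (0.03 log units; within the scatter). The 4-methoxyphenyl ketone also stands level with the 4-aminophenyl ketone, at a 1.1-fold higher number from compound 1 to compound 4 (0.04 log units; within the scatter), and keeps the large gap from the 3,4-dichlorophenyl ketone, at a 10-fold lower number from compound 2 to compound 4 (1.01 log units; beyond the scatter), so the earlier whole-aryl comparisons now extend to an aryl group carrying a single methoxy. No supporting evidence bears on why this methoxy can be exchanged for hydrogen.

The compounds shown leave open whether a hydroxyl, a fluorine or a chlorine on this carbon would behave like hydrogen. They also leave open whether the remaining methoxy matters, which a plain phenyl ketone would test.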